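The source may hold more compounds than are shown below. What is called first, only, known or untested is meant among the compounds shown, and "the series" means these compounds.

Compound 1, `CCc1nc(Cl)c2n1CCN([C@@H](C(=O)NC)c1ccccc1)[C@H]2CCc1cccc(C(F)(F)F)c1`: 10 nM
Compound 2, `CCc1nc(Cl)c2n1CCN([C@@H](C(=O)NC)c1ccccc1)[C@H]2CCc1ccc(C(F)(F)F)c(Cl)c1`: 18 nM
Compound 3, `CNC(=O)[C@@H](c1ccccc1)N1CCn2c(C3CC3)nc(Cl)c2[C@@H]1CCc1cccc(C(F)(F)F)c1`: 7 nM

In a functional assay on CHO cells for antagonist activity at Orexin receptor type 2 (Homo sapiens), read by FLIPR and calcium flux (on this read-out higher numbers stand for weaker inhibition and lower numbers for stronger inhibition), compound 3 gives the lowest number of the three, though the step of a 1.4-fold lower number from compound 1 to compound 3 (0.15 log units; within the scatter) is within the scatter, so compound 3 and compound 1 cannot be told apart; compound 2 sits further off, beyond the scatter. Compound 4, `CNC(=O)[C@@H](c1ccccc1)N1CCn2c(C3CC3)nc(Cl)c2[C@@H]1CCc1ccc(OC(F)F)c(F)c1`, differs from compound 3 by 4-(difluoromethoxy)-3-fluorophenyl in place of 3-(trifluoromethyl)phenyl on a saturated chain carbon, two bonds along the chain from a saturated ring carbon. Among the compounds with values here, the one measured step at that aryl group is a 1.8-fold higher number from compound 1 to compound 2 (0.26 log units; within the scatter), a small move. The change to compound 4 swaps more of the ring, so a somewhat larger loss is expected, a 2.3-fold higher number from compound 3 to compound 4 (0.36 log units; beyond the scatter). Compound 4 is therefore estimated at 16 nM, within a range of 5 nM to 50 nM.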

Compound 4, half-maximal inhibitory concentration: 2 nM
Compound 4: middle estimate off by 8.0-fold (0.90 log units), on the high side; measured number outside the range, below it.
By their numbers in this assay, from the lowest: compound 4; then compounds 3, 1 and 2 (each within the scatter of the next, the first and the last beyond it).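

Within the data shown here, at this position, the only earlier change stayed small, a 1.8-fold higher number from compound 1 to compound 2 (0.26 log units; within the scatter). In this assay, the new change gives a 3.5-fold lower number from compound 3 to compound 4 (0.54 log units; beyond the scatter), so the aryl group on the chain can lower the number by more than the scatter. Nothing available explains this gain.

Going by these compounds, the difluoromethoxy group and the fluorine enter together, so their separate shares stay open, as does whether the same swap would lower the number with ethyl in place of cyclopropyl. On these data alone, how an amine or a carboxylic acid on this phenyl ring would read also stays open.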